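The source may report more compounds than this note shows. Statements on the series, on what has been measured and on what is new or still open speak of the compounds shown alone.

Of the compounds shown here, three in this set have been measured and a fourth awaits its number. Compound 1 `COc1ccc(Cl)cc1N1CCN(CCCCNc2c(C(C)=O)c(C)nn(C)c2=O)CC1`, compound 2 `COc1ccc(Cl)cc1N1CCN(CCNc2c(C(C)=O)c(-c3ccccc3)nn(C)c2=O)CC1` and compound 3 `CC(=O)c1c(-c2ccccc2)nn(C)c(=O)c1NCCN1CCN(c2ccccc2F)CC1` share a core and a chain to a ring amine bearing an aryl group. In an assay on isolated protein for binding affinity to Alpha-1B adrenergic receptor (Homo sapiens), read by radioligand binding (a higher number here means a weaker inhibitor, a lower number a stronger inhibitor), compound 1 gives 49.1 nM, compound 2 gives 3.95 nM and compound 3 gives 3.77 nM. Compound 3 thus stands at the lowest number of the three, with compound 2 within the scatter of it and compound 1 furthest away. Going by the values given here, the only step that touches the aryl group on the amine nitrogen, a 1.0-fold lower number from compound 2 to compound 3 (0.02 log units; within the scatter), shows that exchanging 5-chloro-2-methoxyphenyl for 2-fluorophenyl moved nothing beyond the scatter.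

Compound 4 `CC(=O)c1c(-c2ccccc2)nn(C)c(=O)c1NCCN1CCN(c2ccccc2Cl)CC1` differs from compound 3 in one place: chloro in place of fluoro on an aromatic carbon of a six-membered aromatic ring of carbon only, ortho to a large group, so that 2-fluorophenyl becomes 2-chlorophenyl. Among the compounds with values here, no measured step bears directly on a halogen swap of this kind; the one step at this aryl group was within the scatter. The expected step is therefore a 1.1-fold higher number from compound 3 to compound 4 (0.03 log units; within the scatter), nothing beyond the scatter. Compound 4 is estimated at 4 nM, with a range from 1.5 nM to 11 nM.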

Compound 4, inhibition constant: 0.75 nM
Estimate against measurement, compound 4: 5.3-fold (0.73 log units) above; measured number below the stated range.
By their numbers in this assay, from the lowest: compound 4; then compounds 3 and 2 (each within the scatter of the next); then compound 1.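

In this assay the identity of the halogen on this aromatic carbon matters: a 5.0-fold lower number from compound 3 to compound 4 (0.70 log units; beyond the scatter) lies beyond the scatter, whereas a 1.0-fold lower number from compound 2 to compound 3 (0.02 log units; within the scatter) at the same aryl group did not, so the earlier step had not shown that this aryl group could move the number at all. The comparison with the larger aryl group now also shifts, since a 5.3-fold lower number from compound 2 to compound 4 (0.72 log units; beyond the scatter) is likewise beyond the scatter, and 2-chlorophenyl separates from 5-chloro-2-methoxyphenyl where 2-fluorophenyl did not. Nothing available explains why chloro and fluoro differ here.

The compounds shown leave open whether bromo, methyl or methoxy in the place of chloro on this carbon would lower the number further or raise it again, and how an unsubstituted phenyl would compare with these halogenated rings. Going by these compounds alone, they also leave open whether the exchange of fluoro for chloro would give a step of similar size on a longer chain, such as the one in compound 1, or with a methyl group in place of the phenyl on the core.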